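The source may hold more compounds than are shown below. What is called first, only, known or untested is meant among the compounds shown, and "the series" means these compounds.

Compound 1 `c1ccc2c(-c3cn4ccnc4c(-c4ccc5ncn(C6CCCCC6)c5c4)n3)cccc2c1` and compound 2 `O=Cc1ccc(-c2cn3ccnc3c(-c3ccc4ncn(Cc5ccccc5)c4c3)n2)cc1` share a common core and were both tested in a functional assay on PC-3 cells (Homo sapiens) for inhibition, read by sulforhodamine B assay, with a stated time of 48 h, tested at 10 uM; a lower number here means less inhibition, a higher number more inhibition at the concentration tested (going by the name of the read-out). Compound 1 gives 36.5% in this assay, while compound 2 gives 19%, the lowest of the two numbers and beyond the scatter below compound 1. Compound 3 `c1ccc(Cn2cnc3ccc(-c4nc(-c5cccc6ccccc56)cn5ccnc45)cc32)cc1` is not yet measured; it differs from compound 2 in one place, (naphthalen-1-yl in place of 4-formylphenyl on an aromatic carbon). Compound 1 carries the same naphthalen-1-yl group and gives 36.5%. Among the compounds with values here, on this basis an upward step is expected a number 11 percentage points higher from compound 2 to compound 3 (beyond the scatter), though no step between measured compounds confirms it. Compound 3 is estimated at 30%, between 12% and 50%.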

Compound 3, a percentage reported as inhibition, at one concentration (the size of the read-out at that concentration, not a potency): 31.4%
For compound 3 the middle estimate is 1.4 percentage points below the measured one; low and high end bracket the measured number.
By their numbers in this assay, from the lowest: compound 2; then compounds 3 and 1 (each within the scatter of the next).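

In this assay, the change from 4-formylphenyl to naphthalen-1-yl on this aromatic carbon now has a direct measure, a number 12.4 percentage points higher from compound 2 to compound 3 (beyond the scatter); before, these groups sat on compounds that also differed on the aromatic nitrogen. That nitrogen change can now be read alone: benzyl in place of cyclohexyl gives a number 5.1 percentage points lower from compound 1 to compound 3 (within the scatter). No measurement here gives a reason for either step. Still open, from the compounds shown here alone, is whether the step from compound 2 comes from the second aromatic ring or from losing the formyl group. Plain phenyl at this carbon, or an aminophenyl group, would help separate those two.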